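The compounds below may be only part of what the source reports. "The series", "measured", "known", "first", "only" and "open" are said of these compounds alone.

Compound 1 `O=C(O)C(CCC/C=C(\c1ccccc1)c1cccnc1)Sc1ccccc1`: 33 nM
Compound 2 `O=C(O)CCCC/C=C(\c1cccnc1)c1ccsc1`: 31 nM
Compound 3 `O=C(O)C(CCC/C=C(\c1ccccc1)c1cccnc1)C1=CCCC1`: 60 nM

Of the compounds shown here, three have been measured in an assay (Equus caballus) for inhibition of Thromboxane-A synthase (Homo sapiens), using microsomes; on this read-out higher numbers stand for weaker inhibition and lower numbers for stronger inhibition. Compound 3 carries the highest of the three numbers, but it is not set apart: the step of a 1.8-fold higher number from compound 1 to compound 3 (0.26 log units; within the scatter) stays within the scatter, and the value of compound 2 sits equally close to that of compound 3, so no order among the three can be read from these numbers.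

Compound 4 `C=CCC(CCC/C=C(\c1ccccc1)c1cccnc1)C(=O)O` differs from compound 3 in a single place: allyl in place of cyclopent-1-en-1-yl on a saturated chain carbon bound to a carbonyl carbon and a saturated chain carbon. Among the compounds with values here, the one measured step that touches this same place is a 1.8-fold higher number from compound 1 to compound 3 (0.26 log units; within the scatter), where a quite different group was exchanged at that carbon without moving the number beyond the scatter. Compound 2, which bears no substituent at all at that position on a related chain, also gives a value close to that of compound 3. Nothing measured here suggests that this site is sensitive to the group it carries.

Compound 4 is therefore expected to give about 50 nM in this assay, with a likely range from 25 nM to 120 nM, the expected step of a 1.2-fold lower number from compound 3 to compound 4 (0.08 log units; within the scatter) lying within the scatter.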

Compound 4, half-maximal inhibitory concentration: 50 nM
Compound 4: the middle estimate sits on the measured number at the digits printed, within the range that was stated.
By their numbers in this assay, from the lowest: compounds 2, 1, 4 and 3 (each within the scatter of the next).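

In this assay, allyl at the saturated chain carbon bound to a carbonyl carbon and a saturated chain carbon gives a step of a 1.2-fold lower number from compound 3 to compound 4 (0.08 log units; within the scatter) against cyclopent-1-en-1-yl and of a 1.5-fold higher number from compound 1 to compound 4 (0.18 log units; within the scatter) against phenylsulfanyl. With compound 4, this place now holds a group with no ring, and its number lies within the scatter of those of both ring-bearing compounds, so among these three compounds a ring at this carbon makes no difference that can be read. Nothing available explains this tolerance.

The compounds shown leave open whether an amine, a hydroxyl group or a longer chain at this carbon would also stay within the scatter. They also leave open what a bare chain carbon would give on the core of compound 4, since compound 2 differs from it in more than one place.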